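The source may hold more compounds than are shown below. What is called first, only, known or untested is meant among the compounds shown, and "the series" means these compounds.

Of the compounds shown here, three have been measured in a functional assay on MCF7 cells (Homo sapiens) for antiproliferative activity, read by MTT assay, with a stated time of 72 h; a higher number here means a weaker inhibitor, a lower number a stronger inhibitor.

Compound 1 `O=C1O[C@H]([C@@H](O)Cn2cc(-c3cc(F)cc(F)c3)nn2)C(OCc2ccccc2)=C1OCc1ccccc1`: compound 1 gives 27700 nM.
Compound 2 `O=C1O/C(=C\Cn2cc(-c3cccc(O)c3)nn2)C(OCc2ccccc2)=C1OCc1ccccc1`: compound 2 gives 27800 nM.
Compound 3 `CCCCCc1ccc(-c2cn(C/C=C3\OC(=O)C(OCc4ccccc4)=C3OCc3ccccc3)nn2)cc1`: compound 3 reaches only a limit of the assay, > 100000 nM.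

Compound 1 and compound 2 sit within the scatter of each other, so no order between them can be claimed; compound 3 stands apart as the limit case, (the limit of > 100000 nM in this assay, at which 1 of the 3 values shown sits). Among the measured compounds shown here, the one measured step, an at least 3.5-fold higher number from compound 2 to compound 3 (0.55 log units; beyond the scatter), shows that a larger aryl group at the ring position moves the number toward the limit.

Compound 4 `Cc1ccc(-c2cn(C[C@H](O)[C@H]3OC(=O)C(OCc4ccccc4)=C3OCc3ccccc3)nn2)cc1` is not yet measured. It differs from compound 1 by 4-methylphenyl in place of 3,5-difluorophenyl on an aromatic carbon. This resembles the swap in compound 2 to compound 3 only loosely, since 4-methylphenyl is a far smaller addition than 4-pentylphenyl, and the two pairs share a different linker. The step is therefore expected to stay small, and compound 4 is estimated at 35000 nM, between 12000 nM and 100000 nM, meaning an expected step of a 1.3-fold higher number from compound 1 to compound 4 (0.10 log units; within the scatter).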

Compound 4, half-maximal inhibitory concentration: > 100000 nM
Compound 4: no number, only a limit (the forecaster's own chance of this, stated with the estimate: 20%); middle value at least 2.8-fold (0.45 log units) from the limit.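

Replacing 3,5-difluorophenyl with 4-methylphenyl in this assay gives an at least 3.6-fold higher number from compound 1 to compound 4 (0.55 log units; beyond the scatter), so a chain as long as the pentyl of compound 3 is not needed for a step of this kind at this position. The earlier step, an at least 3.5-fold higher number from compound 2 to compound 3 (0.55 log units; beyond the scatter), was seen on the linker with the double bond, and this one is seen on the linker with the hydroxyl, so the two linkers now each show a step toward the limit when a 4-alkylphenyl group enters. Compound 4 gives only a limit, so its step has a floor and no exact size: the limit of > 100000 nM in this assay, at which 2 of the 4 values shown sit.

The compounds shown leave open whether the methyl group or the loss of the two fluorines drives this step, as both changes come together in it. They also leave open how an amine or a carboxylic acid on the aryl ring would read.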